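Replacing a Cyclopentyl Amide with an Oxanyl Amide

This account rests on a few compounds, and the source may have more. Where it says the series, first, only, none or still open, it means among the compounds named here.

Compound 1 `O=C(C1CCCC1)N1N=CCC1c1ccccc1` is the reference point of this small set. In a physicochemical assay for lipophilicity, read by HPLC, measured as chromatographic lipophilicity, at pH 7.4 (on this read-out higher numbers stand for higher lipophilicity and lower numbers for lower lipophilicity), compound 1 gives 5.4, the highest of the three numbers measured. Compound 2 `CC(C)(C)C(=O)N1N=CCC1c1cc[nH]n1` gives 2.7 in this assay, and compound 3 `O=C(C1CCN(c2cccnn2)CC1)N1N=CC[C@H]1c1ccccc1` gives 3.4; both lie well below compound 1, beyond the usual scatter, though no single-change step connects either of them to compound 1, so the numbers are shown only for orientation.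

Compound 4 `O=C(C1CCOCC1)N1N=CCC1c1ccccc1` has not yet been measured in this assay. It differs from compound 1 in one place: oxan-4-yl in place of cyclopentyl on a carbonyl carbon. Going by the values given here, no measured pair in this set shows what such an exchange does, so the expectation rests on the change itself and on where compound 1 stands. A downward step of moderate size, clearly beyond the scatter, is expected from compound 1 to compound 4, namely a number 1.20 log units lower from compound 1 to compound 4 (beyond the scatter). Compound 4 is therefore estimated to give 4.2 in this assay, with a likely range from 3.6 to 4.8.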

Compound 4, distribution coefficient: 3.1
Beside the measured number, compound 4's estimate is 1.10 log units above it, outside the stated range (below it).
By their numbers in this assay, from the lowest: compound 2; then compounds 4 and 3 (each within the scatter of the next); then compound 1.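

In this assay, going by these compounds alone, the exchange of cyclopentyl for oxan-4-yl on a carbonyl carbon gives a number 2.30 log units lower from compound 1 to compound 4 (beyond the scatter) and so provides the first single-change reading in this set. It shows that this place on the shared core strongly affects the read-out, since one exchange here yields a large step with all else held constant. The entering group brings a six-membered ring with one hetero atom and one hydrogen-bond acceptor, but nothing available accounts for the size of the step.

The compounds shown leave open whether the oxygen or the larger ring carries the step, which a cyclohexyl or an open methoxyethyl chain at this place would help to separate. They also leave open whether the same exchange would give a step of similar size on a different core.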